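A few compounds are considered here, and "the series" means these few. Any claim that something is new, unique, unknown or untested is made for them only; others in the source may bear on it.

Compound 3 `Cc1nnc(SCc2cc(=O)c3cc(Cl)ccc3o2)o1` has no measured number yet in a functional assay on HEp-2 cells (Homo sapiens) for cytotoxicity, read by MTT assay, with a stated time of 72 h; on this read-out lower numbers stand for stronger inhibition and higher numbers for weaker inhibition; it stands at the assay limit, reported as > 25000 nM. The two other compounds in the set sit at the same limit. Compound 1 `Cc1nnc(SCc2cc(=O)c3ccccc3o2)s1` is reported in this assay as > 25000 nM. Compound 2 `Cc1ccc2oc(CSc3nc4nc(C)cc(C)n4n3)cc(=O)c2c1` is reported in this assay as > 25000 nM. Compound 4 `Cc1nnc(SCc2cc(=O)c3ccccc3o2)o1` differs from compound 3 by one change: hydrogen in place of chloro on an aromatic carbon. For the measured compounds named here, no measured pair makes this change, so the expected step in this assay is a step that the limit leaves unreadable from compound 3 to compound 4, none beyond the usual scatter, because of the limit of > 25000 nM in this assay, at which 3 of the 3 values shown sit. Compound 4 is therefore estimated at 40000 nM, within 20000 nM to 100000 nM, most likely again only a limit.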

Compound 4, half-maximal inhibitory concentration: > 25000 nM
Compound 4: no number, only a limit (the forecaster's own chance of this, stated with the estimate: 90%); the middle value lies beyond the limit too.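

The steps to compound 4 from compound 3 and from compound 1 cannot be read, because both ends of each step are limits: the limit of > 25000 nM in this assay, at which 4 of the 4 values shown sit. The compounds shown leave open whether either change affects cytotoxicity at all.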